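Moving from 3-methylphenyl to 4-hydroxyphenyl

The source may hold more compounds than are shown below. What is called first, only, known or untested is meant among the compounds shown, and "the series" means these compounds.

Measured in a functional assay on HepG2 cells (Homo sapiens) for antiproliferative activity, read by MTT assay, with a stated time of 48 h; on this read-out higher numbers stand for weaker inhibition of growth and lower numbers for stronger inhibition of growth:
- compound 1 `COC(=O)N1N=C(c2ccc(OC)cc2)CC1c1cc(OC)c(OC)c(OC)c1`: 1710 nM
- compound 2 `COC(=O)N1N=C(c2cccc(O)c2)CC1c1cc(OC)c(OC)c(OC)c1`: 650 nM
- compound 3 `COC(=O)N1N=C(c2cccc(C)c2)CC1c1cc(OC)c(OC)c(OC)c1`: 980 nM

Compound 3 gives 980 nM, a number within the scatter of both other compounds. The two steps that reach it show this: a 1.7-fold lower number from compound 1 to compound 3 (0.24 log units; within the scatter), and a 1.5-fold higher number from compound 2 to compound 3 (0.18 log units; within the scatter).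

The next compound is compound 4 `COC(=O)N1N=C(c2ccc(O)cc2)CC1c1cc(OC)c(OC)c(OC)c1`, which has not yet been measured. It carries 4-hydroxyphenyl in place of 3-methylphenyl on a carbon with a double bond to nitrogen, on the shared core: 4-hydroxyphenyl in place of 3-methylphenyl on a carbon with a double bond to nitrogen.

Within the data shown here, two measured steps bear on this change. Methyl in place of hydroxy on an aromatic carbon gave a 1.5-fold higher number from compound 2 to compound 3 (0.18 log units; within the scatter), which suggests that this exchange alone matters little. Replacing 4-methoxyphenyl with 3-hydroxyphenyl gave a 2.6-fold lower number from compound 1 to compound 2 (0.42 log units; beyond the scatter), a modest step beyond the scatter. Among the measured compounds shown here, no measured step compares 3-hydroxyphenyl directly with 4-hydroxyphenyl, so the uncertainty stays wide.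

In this assay, no step beyond the scatter is therefore expected, in either direction. The estimated step is a 1.1-fold lower number from compound 3 to compound 4 (0.04 log units; within the scatter). For compound 4 the expected value is 900 nM, with an estimated range from 400 nM to 2000 nM.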

Compound 4, concentration for 50% growth inhibition: 7820 nM
Estimate against measurement, compound 4: 8.7-fold (0.94 log units) below; the measured number lies above the stated range.
By their numbers in this assay, from the lowest: compounds 2, 3 and 1 (each within the scatter of the next, the first and the last beyond it); then compound 4.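

In this assay, the place of the hydroxy group on the phenyl ring proves to matter a great deal: 4-hydroxyphenyl in place of 3-hydroxyphenyl gives a 12-fold higher number from compound 2 to compound 4 (1.08 log units; beyond the scatter), the largest step among these compounds. The earlier small difference between hydroxy and methyl therefore does not carry over to this new group, since 4-hydroxyphenyl in place of 3-methylphenyl gives an 8.0-fold higher number from compound 3 to compound 4 (0.90 log units; beyond the scatter). Removing the methyl from the oxygen of the 4-methoxyphenyl group also gives a 4.6-fold higher number from compound 1 to compound 4 (0.66 log units; beyond the scatter), so compound 4 is the weakest inhibitor of growth of the four, beyond the scatter of each of the others, and a free hydroxy group on an aromatic ring does not bring stronger inhibition in every place it stands.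

No measurement available here explains why these two hydroxyphenyl groups differ so sharply. On these data alone, it remains open how an amine or a carboxylic acid in place of the hydroxy group of compound 4 would read, and whether either would stay close to compound 4 or come nearer to compound 2.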